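Replacing a Small Amide Substituent with a Urea-Bearing Azetidine

The compounds below may be only part of what the source reports. "The series", "measured", "known", "first", "only" and "open" are said of these compounds alone.

Three compounds have so far been measured in a functional assay on MIA PaCa-2 cells (Homo sapiens) for inhibition, read by MTT assay, with a stated time of 3 days; on this read-out lower numbers stand for stronger inhibition and higher numbers for weaker inhibition:

Compound 1, `CCN(CC)S(=O)(=O)c1ccc(S(=O)(=O)N2CCC[C@@H](C(=O)N(C)C(C)C)C2)cc1`, gives 1400 nM.
Compound 2, `CCOC(=O)[C@@H]1CCCN(S(=O)(=O)c2ccc(S(=O)(=O)N(CC)CC)c(F)c2)C1`, gives 200 nM.
Compound 3, `CCOC(=O)[C@@H]1CCCN(S(=O)(=O)c2ccc(S(=O)(=O)N3CCCCC3)cc2)C1`, gives 1000 nM.

Compound 1 stands at the highest number of the three, which on this read-out means the weakest inhibition. Its nearest neighbour is compound 3, whose number lies within the usual scatter of compound 1, so the two cannot be told apart. Compound 2 gives a number that is clearly lower than that of compound 1, beyond the scatter. Within the data shown here, compound 2 and compound 3 each differ from compound 1 in more than one place, so no single structural step links them to compound 1, and their values show only where they stand.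

Compound 4, `CCN(CC)S(=O)(=O)c1ccc(S(=O)(=O)N2CCC[C@@H](C(=O)NC3CN(C(=O)NC(C)(C)C)C3)C2)cc1`, differs from compound 1 in exactly one place: (1-((tert-butyl)carbamoyl)azetidin-3-yl)amino in place of isopropyl(methyl)amino on a carbonyl carbon. Among the measured compounds shown here, the measured set contains no pair that isolates this change, so there is no precedent for its size or direction. The expectation for compound 4 is therefore a step from compound 1 of a 1.1-fold higher number from compound 1 to compound 4 (0.06 log units; within the scatter), not clearly beyond the scatter in either direction. On that basis compound 4 is estimated at 1600 nM, with a plausible range from 400 nM to 6000 nM.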

Compound 4, half-maximal inhibitory concentration: 1400 nM
For compound 4 the middle estimate is 1.1-fold (0.06 log units) above the measured one, and the stated range covers the measured number.
By their numbers in this assay, from the lowest: compound 2; then compounds 3, 1 and 4 (each within the scatter of the next).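

In this assay, the read-out shows no change at the digits printed from compound 1 to compound 4 (within the scatter) on replacing isopropyl(methyl)amino with (1-((tert-butyl)carbamoyl)azetidin-3-yl)amino on a carbonyl carbon. Among these compounds, this is the first single-place comparison in the set, and it shows that this position of compound 1 can take a far larger group without a detectable shift in the number: 12 heavy atoms enter where 5 leave, along with a four-membered ring and 2 hydrogen-bond donors where there were none. No supporting measurement is available to explain why the number holds steady through so large a change in the group.

This single pair cannot show whether the position accepts almost anything or whether these two groups simply happen to match, so a carboxylic acid or a plain unsubstituted amino group on the same carbonyl carbon remains an open test. Also open, from the compounds shown here alone, is whether the azetidine needs its tert-butyl carbamoyl group, and whether the same replacement would leave the number unchanged on a core carrying a fluorine on the aromatic ring.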